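The source may hold more compounds than are shown below. What is called first, only, known or untested is meant among the compounds shown, and "the series" means these compounds.

Series read in a functional assay on MKN-45 cells (Homo sapiens) for antiproliferative activity, read by MTT assay, with a stated time of 72 h, tested at 10 uM; a lower number here means less inhibition, a higher number more inhibition at the concentration tested (going by the name of the read-out); values measured so far:

compound 1 `O=C(Nc1cc(Oc2ccc(Nc3nccc4[nH]cc(-c5ccc(F)cc5)c(=O)c34)cc2F)ccn1)C1CCC1`: 52.8%
compound 2 `O=C(Nc1cc(Oc2ccc(Nc3nccc4[nH]cc(-c5ccc(F)cc5)c(=O)c34)cc2F)ccn1)C1CC1`: 81.8%
compound 3 `CC(C)C(=O)Nc1cc(Oc2ccc(Nc3nccc4[nH]cc(-c5ccc(F)cc5)c(=O)c34)cc2F)ccn1`: 95.4%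

Compound 1 stands lowest of the three. Its nearest neighbour is compound 2, the step being a number 29 percentage points higher from compound 1 to compound 2 (beyond the scatter); the furthest is compound 3, with a number 42.6 percentage points higher from compound 1 to compound 3 (beyond the scatter). Between the two higher compounds the step is a number 13.6 percentage points higher from compound 2 to compound 3 (beyond the scatter).

The next compound, compound 4 `CCCCC(=O)Nc1cc(Oc2ccc(Nc3nccc4[nH]cc(-c5ccc(F)cc5)c(=O)c34)cc2F)ccn1`, differs from compound 1 in one place: butyl in place of cyclobutyl on a carbonyl carbon.

Both steps that start from compound 1 leave the cyclobutyl and both go upward; the larger of them, to compound 3, also exchanges the ring for an acyclic group, as the step to compound 4 does. No butyl amide is among the measured compounds, so the size is uncertain, but an upward step beyond the scatter is expected for compound 4, of a size around a number 19.2 percentage points higher from compound 1 to compound 4 (beyond the scatter). Compound 4 is therefore estimated at 72% in this assay, with a range from 48% to 93%.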

Compound 4, a percentage reported as inhibition, at one concentration (the size of the read-out at that concentration, not a potency): 62.7%
Compound 4: middle estimate off by 9.3 percentage points, on the high side; measured number inside the range.
By their numbers in this assay, from the lowest: compounds 1 and 4 (each within the scatter of the next); then compound 2; then compound 3.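

In this assay, butyl in place of cyclobutyl on the carbonyl carbon gives a number 9.9 percentage points higher from compound 1 to compound 4 (within the scatter) and so, unlike the steps to the cyclopropyl and isopropyl groups, leaving the ring does not here move the number beyond the scatter. An open chain alone is not enough either: butyl in place of isopropyl gives a number 32.7 percentage points lower from compound 3 to compound 4 (beyond the scatter) and butyl in place of cyclopropyl gives a number 19.1 percentage points lower from compound 2 to compound 4 (beyond the scatter) in this series. At this position the read-out thus follows the particular group rather than ring against open chain, since compound 2 and compound 3 read high with one of each, as compound 1 and compound 4 read low with one of each. Nothing at hand explains these steps.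

Open, going by these compounds, is whether a propyl, a tert-butyl, a cyclopentyl or a longer chain on the carbonyl carbon would read with compound 3 or with compound 4. A read-out at one concentration also leaves the potency of all four compounds open.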